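Swapping phenyl for furan-3-yl on a weakly active nucleoside

This account rests on a few compounds, and the source may have more. Where it says the series, first, only, none or still open, it means among the compounds named here.

Compound 2 `CSc1ncnc2c1c(-c1ccccc1)cn2[C@@H]1O[C@H](CO)[C@@H](O)[C@H]1O` is one of three compounds tested in a functional assay on HCT-116 cells (Homo sapiens), read by MTT assay, with a stated time of 72 h; a lower number here means a stronger inhibitor, a higher number a weaker inhibitor. In this assay compound 2 gives only a limit, > 20000 nM. Compound 3 `CNc1ncnc2c1c(-c1ccccc1)cn2[C@@H]1O[C@H](CO)[C@@H](O)[C@H]1O` likewise gives only a limit, > 20000 nM. The step from compound 2 to compound 3, a step that the two limits leave unreadable from compound 2 to compound 3, therefore says nothing about size, as the limit of > 20000 nM in this assay, at which 2 of the 3 values shown sit, shows. Compound 1 `COc1ncnc2c1c(-c1ccoc1)cn2[C@@H]1O[C@H](CO)[C@@H](O)[C@H]1O` gives 110 nM. Compound 4 `CSc1ncnc2c1c(-c1ccoc1)cn2[C@@H]1O[C@H](CO)[C@@H](O)[C@H]1O` differs from compound 2 by furan-3-yl in place of phenyl on an aromatic carbon. Among the measured compounds shown here, no measured step covers this change on its own, so the expectation rests on compound 1 carrying the same furan-3-yl with a number rather than a limit. Compound 4 is expected to give 3000 nM, within 150 nM to 20000 nM. That estimate means a step of an at least 6.6-fold lower number from compound 2 to compound 4 (0.82 log units; beyond the scatter) toward stronger inhibition.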

Compound 4, half-maximal inhibitory concentration: 40 nM
Compound 4: middle estimate off by 75-fold (1.88 log units), on the high side; the measured number lies below the stated range.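

In this assay, with methylsulfanyl held constant, furan-3-yl in place of phenyl gives an at least 500-fold lower number from compound 2 to compound 4 (2.69 log units; beyond the scatter), so this single ring change at this position turns a compound without a readable number into a strong inhibitor. Compound 2 gives only a limit, so that size is a floor: the limit of > 20000 nM in this assay, at which 2 of the 4 values shown sit. With furan-3-yl kept, methylsulfanyl in place of methoxy gives a 2.8-fold lower number from compound 1 to compound 4 (0.44 log units; beyond the scatter), a modest step next to the ring change.

Still open, going by these compounds, is whether furan-3-yl would lift the methylamino compound 3 in the same way, and whether thiophen-3-yl or furan-2-yl at this position would do as well.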